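The source may hold more compounds than are shown below. What is called first, only, known or untested is meant among the compounds shown, and "the series" means these compounds.

Measured so far in an assay on THP-1 cells for displacement of a labelled ligand from C-C chemokine receptor type 1 (Homo sapiens); a higher number here means a weaker inhibitor, a lower number a stronger inhibitor:
Compound 1, `CC(C)C(NC(=O)c1ccccc1)C(=O)N1CCC(c2ccc(F)cc2)CC1`: compound 1 gives 423 nM.
Compound 2, `CCCC(NC(=O)c1ccccc1C)C(=O)N1CCC(c2ccc(Cl)cc2)CC1`: compound 2 gives 152 nM.

Compound 2 has the lower of the two numbers in this assay, and its gap to compound 1 is beyond the usual scatter. Among the compounds with values here, compounds 1 and 2 differ in several places at once, so no single-change step between measured compounds is available.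

Compound 3, `Cc1ccccc1C(=O)NC(CC(C)C)C(=O)N1CCC(c2ccc(Cl)cc2)CC1`, is the next compound for this assay. Relative to compound 2 the change is methyl in place of hydrogen on a saturated chain carbon bound to two saturated chain carbons. Within the data shown here, nothing among the measured compounds isolates this change, so the expectation rests on the closeness of compound 3 to compound 2 overall. The step from compound 2 to compound 3 is expected to be small, a 1.3-fold lower number from compound 2 to compound 3 (0.10 log units; within the scatter), in either direction or none beyond the scatter. Compound 3 is therefore estimated at 120 nM in this assay, with a range from 45 nM to 350 nM.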

Compound 3, half-maximal inhibitory concentration: 88 nM
Compound 3: middle estimate off by 1.4-fold (0.13 log units), on the high side, within the range that was stated.
By their numbers in this assay, from the lowest: compounds 3 and 2 (each within the scatter of the next); then compound 1.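

Methyl in place of hydrogen on a saturated chain carbon bound to two saturated chain carbons, which turns propyl into isobutyl, gives a 1.7-fold lower number from compound 2 to compound 3 (0.24 log units; within the scatter) in this assay and provides the first single-change step in the series. This position therefore accepts branching of the chain at this carbon, with compound 2 and compound 3 indistinguishable in this read-out. No available measurement explains the size of this step.

Still open, going by these compounds, is whether this position accepts a longer chain such as pentyl, a ring such as cyclohexyl, or a chain ending in an amine or a carboxylic acid. The compounds shown also leave open whether the same chain change would give a similar step on the core of compound 1, which differs from compound 2 in several places.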